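The source may report more compounds than this note shows. Statements on the series, on what has been measured and on what is new or still open speak of the compounds shown alone.

Three compounds of this series have already been examined in an ADME assay on MT4 cells (Homo sapiens) for cytotoxicity, read by MTT assay, with a stated time of 4 days; on this read-out higher numbers stand for lower toxicity in this test and lower numbers for higher toxicity in this test. Compound 1 `O=C(COc1cccc2ccccc12)N/N=C/c1ccccc1[N+](=O)[O-]` gives 12.2 ug/mL in this assay. Compound 2 `O=C(COc1cccc2ccccc12)N/N=C/c1ccc([N+](=O)[O-])cc1` gives 87.9 ug/mL, and compound 3 `C/C(=N\NC(=O)COc1cccc2ccccc12)c1ccc([N+](=O)[O-])cc1` gives 89.3 ug/mL. Among these three numbers compound 2 stands second highest; its nearest neighbour is compound 3, whose number lies within the scatter of that of compound 2, while compound 1 stands furthest away, with a number beyond the scatter and lower than that of compound 2.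

Compound 4 `COc1ccc(/C=N/NC(=O)COc2cccc3ccccc23)cc1` has not yet been measured in this assay. It differs from compound 2 in one place: methoxy in place of nitro on an aromatic carbon. Going by the values given here, no pair of measured compounds in this set covers this change, so there is no direct precedent for it here. What compound 2 and compound 3 do show is that the upper part of the range is reached while the nitro group is still present on the shared core. The step from compound 2 to compound 4 is expected to be small, within the scatter or close to it, with no clear direction: a 1.1-fold lower number from compound 2 to compound 4 (0.04 log units; within the scatter). Compound 4 is therefore estimated at 80 ug/mL in this assay, with a range from 30 ug/mL to 200 ug/mL.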

Compound 4, half-maximal cytotoxic concentration: 76.9 ug/mL
Estimate against measurement, compound 4: 1.0-fold (0.02 log units) above; the range from low to high includes it.
By their numbers in this assay, from the lowest: compound 1; then compounds 4, 2 and 3 (each within the scatter of the next).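

In this assay, methoxy in place of nitro, on an aromatic carbon para to a large group, amounts to a 1.1-fold lower number from compound 2 to compound 4 (0.06 log units; within the scatter), so at this place the two groups cannot be told apart by this read-out. All three earlier compounds carried a nitro group, so they could not show whether the number of compound 2 depended on that group; compound 4 has no nitro group at all and still reads within the scatter of compound 2, which shows that, on this core, the nitro group is not required at this place for a number in the upper part of the range. Nothing available here bears on why the exchange leaves the number where it stands.

Going by these compounds, the two groups tested here say nothing about others at the same place, such as an amine, a carboxylic acid or a chlorine atom, so it remains open whether this place tolerates any exchange or only these two groups. On these data alone, it also remains open how methoxy would read at the place where compound 1, at 12.2 ug/mL, bears its nitro group.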